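Shifting the Chlorine on the Urea Tail

This account rests on a few compounds, and the source may have more. Where it says the series, first, only, none or still open, it means among the compounds named here.

Measured compounds:
compound 1, `CN(C)CCCNc1nc(-c2ccc(NC(=O)Nc3ccc(Cl)cc3)cc2)nc2c(Cl)c(Cl)sc12`, 1530 nM
compound 2, `CN(C)CCCNc1nc(-c2ccc(NC(=O)Nc3ccccc3Cl)cc2)nc2c(Cl)c(Cl)sc12`, 1330 nM
compound 3, `CN(C)CCNc1nc(-c2ccc(NC(=O)Nc3ccc(Cl)cc3)cc2)nc2ccsc12`, 250 nM

All three were tested in a functional assay on MKN-45 cells (Homo sapiens) for cytotoxicity, read by MTT assay, with a stated time of 72 h; on this read-out higher numbers stand for weaker inhibition and lower numbers for stronger inhibition. Compound 1 and compound 2 share one core, and they differ only in the change (2-chlorophenyl in place of 4-chlorophenyl on an amide-type nitrogen). This change gave a 1.2-fold lower number from compound 1 to compound 2 (0.06 log units; within the scatter), so the two values cannot be told apart.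

Compound 3 carries a different core from compound 1; the difference between the two cores is not broken down here. In this assay compound 3 gives 250 nM, the lowest of the three numbers, and its gaps to compound 1 and compound 2 are both beyond the usual scatter.

Compound 4, `CN(C)CCNc1nc(-c2ccc(NC(=O)Nc3ccccc3Cl)cc2)nc2ccsc12`, has not yet been measured. It stands to compound 3 as compound 2 stands to compound 1: the change is 2-chlorophenyl in place of 4-chlorophenyl on an amide-type nitrogen, made at the same kind of place, on an amide-type nitrogen whose other neighbour is the carbonyl carbon. Since the same change on the other core produced only a 1.2-fold lower number from compound 1 to compound 2 (0.06 log units; within the scatter), a step of similar size is expected here, a 1.0-fold lower number from compound 3 to compound 4 (0.02 log units; within the scatter). Compound 4 is therefore expected to give about 240 nM in this assay, most likely between 100 nM and 600 nM.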

Compound 4, half-maximal inhibitory concentration: 850 nM
Estimate against measurement, compound 4: 3.5-fold (0.55 log units) below; the whole stated range lies below it.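

On the core of compound 3, putting 2-chlorophenyl in place of 4-chlorophenyl on the amide-type nitrogen matters in this assay: the step is a 3.4-fold higher number from compound 3 to compound 4 (0.53 log units; beyond the scatter), which means weaker inhibition on this core. The same swap therefore does not carry over unchanged from one core to the other, so a result on one core is a poor guide to the other here: the same change on two cores in this assay, a 1.2-fold lower number (0.06 log units; within the scatter) from compound 1 to compound 2 and a 3.4-fold higher number (0.53 log units; beyond the scatter) from compound 3 to compound 4, 3.9-fold (0.59 log units) apart, beyond the scatter of two such steps. Among the compounds shown here, this does not show which part of the difference between the two cores is responsible, and with only one pair on each core it says nothing about how the swap would behave on any further core.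

As far as these compounds go, it remains open whether a plain phenyl or a fluorophenyl on the same amide-type nitrogen would also respond differently on the two cores. From the compounds shown here alone, it is equally open whether a morpholine in place of the dimethylamino group at the end of the side chain would change the picture.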